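A few compounds are considered here, and "the series" means these few. Any claim that something is new, unique, unknown or untested is made for them only; others in the source may bear on it.

In a functional assay on A549 cells (Homo sapiens) for inhibition, read by CCK-8 assay, with a stated time of 72 h, tested at 10 uM (a higher number here means more inhibition of growth at the concentration tested, a lower number less inhibition of growth), compound 1 `Cc1cccc(NC(=O)C2(C(=O)Nc3ccc(Nc4ncc5cc(C(=O)N(C)C)n(C6CCCC6)c5n4)cc3)CC2)c1` reaches 86.1% while compound 2 `COC(=O)c1ccc(NC(=O)C2(C(=O)Nc3ccc(Nc4ncc5cc(C(=O)N(C)C)n(C6CCCC6)c5n4)cc3)CC2)cc1` reaches 92% and compound 3 `CN(C)C(=O)c1cc2cnc(Nc3ccc(NC(=O)C4(C(=O)Nc5ccc(Br)cc5)CC4)cc3)nc2n1C1CCCC1` reaches 90.3% at the single concentration tested. Compound 3 cannot be told apart from the other two: the data show a number 1.7 percentage points lower from compound 2 to compound 3 (within the scatter) and also a number 4.2 percentage points higher from compound 1 to compound 3 (within the scatter) on the way to it.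

The unmeasured compound 4 `CN(C)C(=O)c1cc2cnc(Nc3ccc(NC(=O)C4(C(=O)Nc5cccc(C(F)(F)F)c5)CC4)cc3)nc2n1C1CCCC1` differs from compound 3 in one place: 3-(trifluoromethyl)phenyl in place of 4-bromophenyl on an amide-type nitrogen with 3-(trifluoromethyl)phenyl in place of 4-bromophenyl on an amide-type nitrogen. The best guides are the earlier exchanges of the group on that same nitrogen. Replacing 3-methylphenyl gave a number 5.9 percentage points higher from compound 1 to compound 2 (within the scatter) in one case and a number 4.2 percentage points higher from compound 1 to compound 3 (within the scatter) in the other, and the exchange between the remaining pair gave a number 1.7 percentage points lower from compound 2 to compound 3 (within the scatter) as its step. Going by the values given here, all three exchanges stayed small, although none of the measured compounds carries trifluoromethyl, so the guidance is indirect. No step beyond the scatter is therefore expected in this assay in either direction. The expected change is a number 2.3 percentage points lower from compound 3 to compound 4 (within the scatter) as a rough figure. For compound 4 the estimated value is 88% with an expected range from 78% to 96% for this measurement.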

Compound 4, percent growth inhibition at one concentration: 89.2%
For compound 4 the middle estimate is 1.2 percentage points below the measured one; low and high end bracket the measured number.
By their numbers in this assay, from the lowest: compounds 1, 4, 3 and 2 (each within the scatter of the next).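

In this assay a fourth substituted phenyl group on the amide-type nitrogen, 3-(trifluoromethyl)phenyl, gives a number 1.1 percentage points lower from compound 3 to compound 4 (within the scatter) and a number 2.8 percentage points lower from compound 2 to compound 4 (within the scatter) and a number 3.1 percentage points higher from compound 1 to compound 4 (within the scatter) so it cannot be told apart from any of the three earlier groups. The last of these steps is the most direct new comparison, since only trifluoromethyl in place of methyl on an aromatic carbon separates the two compounds, and even this exchange produces no readable difference. Nothing measured here explains why these groups read alike.

As far as these compounds go, all four compounds carry a phenyl ring on this nitrogen, so it remains open whether a phenyl ring bearing a carboxylic acid or an aminomethyl group, or a cyclohexyl ring in place of the phenyl ring, would also stay within the scatter. From the compounds shown here alone, since every reading comes from a single concentration, it also remains open whether full dose-response curves would separate these four compounds.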